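The source may report more compounds than this note shows. Statements on the series, on what has been measured and on what is new or still open speak of the compounds shown alone.

Measured compounds:
Compound 1 `N=C(N)c1ccc(-c2ccc(-c3ccc(F)cc3)o2)o1` gives 90%
Compound 2 `N=C(N)c1ccc(-c2ccc(-c3ccccc3)s2)s1` gives 85.1%
Compound 3 `N=C(N)c1ccc(-c2ccc(-c3ccc4ccccc4c3)s2)s1` gives 21.1%

All three were tested in an ADME assay on cells (Erythrocyte, Homo sapiens) for activation, read by hemolysis, with a stated time of 30 min, tested at 10 mM; a lower number here means a weaker effect, a higher number a stronger effect of the compound at the concentration tested. Among the three numbers, compound 2 stands second highest. Its nearest neighbour is compound 1, whose value lies within the usual scatter of compound 2, so no order can be read between these two. Compound 3 is furthest away, its value lying well beyond the scatter below compound 2.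

Compound 4 `COc1ccc(-c2ccc(-c3ccc(C(=N)N)s3)s2)cc1` has not yet been measured. Among the compounds with values here, it differs from compound 2 in one place: methoxy in place of hydrogen on an aromatic carbon No step between two measured compounds follows this exact change, so the expectation rests on the spread seen so far: compound 1 and compound 2 give close values, while compound 3, carrying a larger outer ring, falls far lower. The methoxy is a smaller addition than that. For compound 4 a modest downward step, or none beyond the scatter, is expected in this assay, namely a number 15.1 percentage points lower from compound 2 to compound 4 (beyond the scatter). Compound 4 is therefore estimated at 70%, with a range from 35% to 95%.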

Compound 4, a percentage reported as activity, at one concentration (the size of the read-out at that concentration, not a potency): 92.7%
Estimate against measurement, compound 4: 22.7 percentage points below; the measured number falls inside the stated range.
By their numbers in this assay, from the lowest: compound 3; then compounds 2, 1 and 4 (each within the scatter of the next).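

In this assay, methoxy in place of hydrogen on an aromatic carbon, para to a large group, gives a number 7.6 percentage points higher from compound 2 to compound 4 (within the scatter) for this single change, so no real shift can be read from it. Within the data shown here, this is the first comparison here in which two measured compounds differ in only one place, and it shows that this spot on the six-membered ring can carry methoxy without a clear move in the read-out. Nothing measured here explains this result.

The compounds shown leave open whether a different group at the same carbon, such as an amine, a carboxylic acid or a longer chain like butoxy, would also leave the number in place. They also leave open whether methoxy would behave the same way at another carbon of that ring.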